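This account rests on a few compounds, and the source may have more. Where it says the series, first, only, none or still open, it means among the compounds named here.

Measured so far in an assay on isolated protein for inhibition of malate dehydrogenase, mitochondrial (Sus scrofa), with stated times of 45 min and 30 min; a higher number here means a weaker inhibitor, a lower number a stronger inhibitor:

- compound 1 `O=S(=O)(Nc1ccc2oc(-c3ccccc3)nc2c1)c1ccccc1C(F)(F)F` gives > 63000 nM, which is a limit of the assay and not a number.
- compound 2 `Cc1cccc(S(=O)(=O)Nc2ccc3oc(-c4ccccc4)nc3c2)c1` gives > 63000 nM, again a limit.
- compound 3 `COc1ccc(S(=O)(=O)Nc2ccc3oc(-c4ccccc4)nc3c2)cc1` gives > 63000 nM, again a limit.

Compound 3 therefore stands nowhere in particular on the numbers shown: it sits at the same limit as the other two, and the step that the two limits leave unreadable from compound 2 to compound 3 cannot be read. Going by the values given here, every value shown is a limit (the limit of > 63000 nM in this assay, at which 3 of the 3 values shown sit), so there is no measured step of known size to lean on.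

Compound 4 `O=S(=O)(Nc1ccc2oc(-c3ccccc3)nc2c1)c1ccccc1F` is the next compound, and it differs from compound 3 in one place: 2-fluorophenyl in place of 4-methoxyphenyl on a sulfonyl sulfur. Among the compounds with values here, no measured step bears directly on this change; the single step from compound 2 to compound 3 is unreadable, and compound 1, whose ring on the sulfonyl sulfur also carries fluorine, sits at the same limit (the limit of > 63000 nM in this assay, at which 3 of the 3 values shown sit).

With three limits and nothing else, compound 4 is expected to stay at a limit as well, and the expected step that the limit leaves unreadable from compound 3 to compound 4 is none beyond the scatter. The estimate for compound 4 in this assay is 120000 nM, with a range from 50000 nM to 400000 nM.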

Compound 4, half-maximal inhibitory concentration: > 63000 nM
Compound 4 ended at the assay's limit (the forecaster's own chance of this, stated with the estimate: 85%); the middle value lies beyond the limit too.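

Going by these compounds alone, no step from compound 1, compound 2 or compound 3 to compound 4 can be read, because all four compounds sit at a limit of the assay and not at a number: the limit of > 63000 nM in this assay, at which 4 of the 4 values shown sit. The compounds shown leave open whether any group on the sulfonyl sulfur gives measurable inhibition, and how these four groups truly compare.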